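The source may report more compounds than this note shows. Statements on the series, on what has been measured and on what is new or still open speak of the compounds shown alone.

In a functional assay on ECa-109 cells for antiproliferative activity against ECa-109 cell line (Homo sapiens), read by MTT assay, with a stated time of 72 h (on this read-out lower numbers stand for stronger inhibition and higher numbers for weaker inhibition), compound 3 (`O=C(N/N=C/c1ccccn1)c1cccc(S(=O)(=O)N2CCOCC2)c1`) gives 55700 nM, the highest number of the three measured compounds. Compound 1 (`C/C(=N\NC(=O)c1cccc(S(=O)(=O)N2CCOCC2)c1)c1ccccc1O`) gives 5450 nM and compound 2 (`C/C(=N\NC(=O)c1cccc(S(=O)(=O)N2CCOCC2)c1)c1cc(F)ccc1O`) gives 3270 nM. Compound 4 (`O=C(N/N=C/c1cc(Cl)ccc1O)c1cccc(S(=O)(=O)N2CCOCC2)c1`) has 5-chloro-2-hydroxyphenyl in place of pyridin-2-yl on a carbon with a double bond to nitrogen. Compound 1 and compound 2 also carry a hydroxyl-bearing ring instead of pyridin-2-yl, but they hold an extra methyl on that carbon, so they are only a rough guide. Going by the values given here, the one measured step, fluoro in place of hydrogen on an aromatic carbon, stays within the scatter (a 1.7-fold lower number from compound 1 to compound 2 (0.22 log units; within the scatter)), so the chlorine is not expected to add much. A clearly lower number is therefore expected in this assay, close to those of compound 1 and compound 2 (a 14-fold lower number from compound 3 to compound 4 (1.14 log units; beyond the scatter)). Compound 4 is estimated at 4000 nM (range 1300 nM to 12000 nM).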

Compound 4, half-maximal inhibitory concentration: 2840 nM
Estimate against measurement, compound 4: 1.4-fold (0.15 log units) above; the range from low to high includes it.
By their numbers in this assay, from the lowest: compounds 4, 2 and 1 (each within the scatter of the next); then compound 3.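

In this assay, 5-chloro-2-hydroxyphenyl in place of pyridin-2-yl on a carbon with a double bond to nitrogen gives a 20-fold lower number from compound 3 to compound 4 (1.29 log units; beyond the scatter). Going by these compounds alone, this shows directly that the group at this position can shift the number greatly, whereas the only earlier step, a 1.7-fold lower number from compound 1 to compound 2 (0.22 log units; within the scatter), stayed within the scatter. No measurement shown explains this change.

Going by these compounds, the step swaps the ring and adds the hydroxyl and chlorine all at once, so the share of each stays open. Also open, on these data alone, is how plain phenyl or a carboxylic acid would behave at this position.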